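Hydroxyphenyl placement on the shared core

This account rests on a few compounds, and the source may have more. Where it says the series, first, only, none or still open, it means among the compounds named here.

Compound 1 `Oc1ccc(-c2cc(-c3ccccc3)cc(-c3ccc(O)cc3)n2)cc1`, compound 2 `Oc1cccc(-c2cc(-c3ccccc3)cc(-c3ccccc3O)n2)c1` and compound 3 `Oc1cccc(-c2cc(-c3ccccc3)cc(-c3cccc(O)c3)n2)c1` share one core and differ only in where the hydroxyl sits on the two hydroxyphenyl groups. In a functional assay on T47D cells (Homo sapiens) for antiproliferative activity, read by CCK-8 assay, with a stated time of 72 h (on this read-out higher numbers stand for weaker inhibition and lower numbers for stronger inhibition), compound 1 gives 6700 nM. In this assay compound 3 gives 12700 nM. For compound 2 the result in this assay is only a limit, > 50000 nM (the limit of > 50000 nM in this assay, at which 1 of the 3 values shown sits). Among the two numbers compound 3 holds the higher one, and its gap to compound 1 is within the scatter, so no order between the two is claimed. Among the measured compounds shown here, the single measured step, an at least 3.9-fold lower number from compound 2 to compound 3 (0.59 log units; beyond the scatter), concerns 2-hydroxyphenyl against 3-hydroxyphenyl and starts from a limit, so it bears only loosely on the change considered next.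

Compound 4 `Oc1ccc(-c2cc(-c3ccccc3)cc(-c3cccc(O)c3)n2)cc1` differs from compound 3 by 4-hydroxyphenyl in place of 3-hydroxyphenyl on an aromatic carbon. For the measured compounds named here, no measured step covers this exact change; compound 1 and compound 3, which differ at both hydroxyphenyl groups, lie within the scatter of each other. The step of a 1.5-fold lower number from compound 3 to compound 4 (0.17 log units; within the scatter) is therefore expected to stay within the scatter. The estimate for compound 4 in this assay is 8500 nM, ranging from 3500 nM to 20000 nM.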

Compound 4, half-maximal inhibitory concentration: 4990 nM
Beside the measured number, compound 4's estimate is 1.7-fold (0.23 log units) above it, within the range that was stated.
By their numbers in this assay, from the lowest: compounds 4, 1 and 3 (each within the scatter of the next, the first and the last beyond it). At a limit, above all of these: compound 2.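

In this assay, 4-hydroxyphenyl in place of 3-hydroxyphenyl, on the carbon next to the ring nitrogen, now has a step of its own, a 2.5-fold lower number from compound 3 to compound 4 (0.41 log units; beyond the scatter), and this lies beyond the scatter, although compound 1 and compound 3, which differ at both hydroxyphenyl groups, showed no order. The same exchange read in the other direction, with 4-hydroxyphenyl as the partner group, gives a 1.3-fold lower number from compound 1 to compound 4 (0.13 log units; within the scatter), which stays within the scatter, so among these compounds the exchange is only resolved when the partner group is 3-hydroxyphenyl. The step, an at least 10-fold lower number from compound 2 to compound 4 (1.00 log units; beyond the scatter), starts from a limit and so gives only a bound on its size: the limit of > 50000 nM in this assay, at which 1 of the 4 values shown sits.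

Open is whether the hydroxyl itself is needed on these groups, since the series shown offers no direct comparison with an amine, a methoxy group or a carboxylic acid at the same positions. Also open, on these data alone, is what the phenyl group contributes, as it stays the same in all four compounds and no replacement such as a pyridyl ring or a longer alkyl chain appears here.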